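A Swap on the Benzylic Arm of a Silent Series

This account rests on a few compounds, and the source may have more. Where it says the series, first, only, none or still open, it means among the compounds named here.

Compound 3 `Cc1ccc2c(NCc3ccc(NC(=O)C4CCN(Cc5ccco5)CC4)cc3)nc(N(C)C)nc2c1` was tested in a functional assay on SV5A8 cells (Homo sapiens) for cytotoxicity; on this read-out higher numbers stand for weaker inhibition and lower numbers for stronger inhibition. In this assay compound 3 gives > 20000 nM, which is a limit of the assay rather than a number, and it sits at the limit of > 20000 nM in this assay, at which 1 of the 3 values shown sits. Two related compounds likewise return only limits. Compound 1 `Cc1ccc2c(NCc3ccc(NC(=O)C4CCN(Cc5ccccc5)CC4)cc3)nc(N3CCCCCC3)nc2c1` gives > 6880 nM in this assay, a limit. Compound 2 `Cc1ccc2c(NCc3ccc(NC(=O)C4CCN(Cc5ccccc5)CC4)cc3)nc(N3CCN[C@@H](C)C3)nc2c1` gives > 8860 nM in this assay, also a limit. Among the measured compounds shown here, the one change joining them, a step that the two limits leave unreadable from compound 1 to compound 2, therefore cannot be read, and it concerns a different part of the molecule from the change considered here.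

Compound 4 `Cc1ccc2c(NCc3ccc(NC(=O)C4CCN(Cc5ccc(Cl)cc5)CC4)cc3)nc(N(C)C)nc2c1` differs from compound 3 by 4-chlorophenyl in place of furan-2-yl on a saturated chain carbon bound to an amine nitrogen in a ring. For the measured compounds named here, no measured step touches this position, so nothing among the three values shows how this assay responds to it. What the three values do show is that every member of the group so far has stayed beyond the reach of the assay, and compound 4 is expected to do the same. The value of compound 4 is estimated at 20000 nM, within 7000 nM to 60000 nM. The expected step of a number no higher from compound 3 to compound 4 (the limit leaves the size open) is therefore no step beyond the scatter. Most likely the assay would again report only a limit for compound 4.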

Compound 4, half-maximal inhibitory concentration: > 3180 nM
Compound 4: only a limit was reported; the forecaster's own chance of this, stated with the estimate: 80%; the middle value is on the limit's open side.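

Compound 3 and compound 4 each return only a limit, so the change to 4-chlorophenyl in place of furan-2-yl cannot be read as a step of any size. None of the four compounds shown gives an actual number in this assay, which leaves open how any change to these structures affects the read-out.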